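This account rests on a few compounds, and the source may have more. Where it says the series, first, only, none or still open, it means among the compounds named here.

Compounds measured in a functional assay on CHO cells for agonist activity at Free fatty acid receptor 1 (Homo sapiens), read by fluorescence and calcium flux; on this read-out lower numbers stand for an effect already at smaller amounts and higher numbers for an effect only at larger amounts of compound:
compound 1 `Cc1cc(OCCCS(C)(=O)=O)cc(C)c1-c1cccc(COc2ccc(OCC(=O)O)cc2)c1`, 121 nM;
compound 2 `Cc1cc(OCCCS(C)(=O)=O)cc(C)c1-c1cccc(COc2ccc(OC(C)C(=O)O)cc2)c1`, 389 nM;
compound 3 `CCc1cc(OCc2cccc(-c3c(C)cc(OCCCS(C)(=O)=O)cc3C)c2)ccc1OCC(=O)O`, "not determined" (no result reported).

Compound 3 therefore stands without a number in this assay; nothing can be said about where it falls relative to compound 1 or compound 2. Among the compounds with values here, the only step among the measured compounds is a 3.2-fold higher number from compound 1 to compound 2 (0.51 log units; beyond the scatter), which concerns the chain carbon and not the aromatic ring.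

Compound 4 `Cc1cc(OCCCS(C)(=O)=O)cc(C)c1-c1cccc(COc2ccc(OCC(=O)O)c(F)c2)c1` differs from compound 3 by fluoro in place of ethyl on an aromatic carbon. No measured step touches this change, so the expectation for compound 4 cannot rest on any step from compound 3, and the size and direction of the change are unknown from the data shown. The nearest measured structure is compound 1, which shares every other feature with compound 4, and in this assay compound 1 gives 121 nM. Compound 4 is expected to land near that figure, with a wide range because compound 1 gives 121 nM without any matched step to show how the new substituent acts.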

Compound 4, half-maximal effective concentration: 62.3 nM
Estimate against measurement, compound 4: 2.4-fold (0.38 log units) above, within the range that was stated.
By their numbers in this assay, from the lowest: compounds 4 and 1 (each within the scatter of the next); then compound 2.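

In this assay, fluoro on the aromatic carbon ortho to a carboxymethoxy group gives a 1.9-fold lower number from compound 1 to compound 4 (0.29 log units; within the scatter), and this step lies within the scatter, so the ring position accepts fluoro in place of hydrogen with no change that can be told apart. The larger step, a 6.2-fold lower number from compound 2 to compound 4 (0.80 log units; beyond the scatter), lies beyond the scatter, but it joins the ring fluoro with the loss of the methyl on the chain carbon, so it gives no separate reading of the ring position. No measurement offered here accounts for either result.

Compound 3 has no number, so the compounds shown leave open how ethyl at this position compares with hydrogen or fluoro. They also leave open how chloro, methoxy or a nitrile would behave on this aromatic carbon.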